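Cytotoxicity of a triazole-linked anilide series: one further fluorine

The source may report more compounds than this note shows. Statements on the series, on what has been measured and on what is new or still open speak of the compounds shown alone.

Three compounds sharing one core were tested in a functional assay on THP-1 cells (Homo sapiens) for cytotoxicity, read by MTT assay, with a stated time of 24 h; on this read-out higher numbers stand for weaker inhibition and lower numbers for stronger inhibition. Compound 1 `CCCCn1cc(Cn2nc(N)c3c(C(F)(F)F)cc(-c4ccccc4)nc32)nn1` gives 46.1 ug/mL in this assay; compound 2 `Nc1nn(Cc2cn(CC(=O)Nc3cccc(Cl)c3)nn2)c2nc(-c3ccccc3)cc(C(F)(F)F)c12` gives 37 ug/mL; compound 3 `Nc1nn(Cc2cn(CC(=O)Nc3cccc(F)c3)nn2)c2nc(-c3ccccc3)cc(C(F)(F)F)c12` gives 99.5 ug/mL. Compound 3 stands at the highest of the three numbers, the weakest inhibitor here: the step of a 2.2-fold higher number from compound 1 to compound 3 (0.33 log units; beyond the scatter) and the step of a 2.7-fold higher number from compound 2 to compound 3 (0.43 log units; beyond the scatter) are both beyond the scatter, while a 1.2-fold lower number from compound 1 to compound 2 (0.10 log units; within the scatter) is not.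

Compound 4 `Nc1nn(Cc2cn(CC(=O)Nc3c(F)cccc3F)nn2)c2nc(-c3ccccc3)cc(C(F)(F)F)c12` is reached from compound 3 by 2,6-difluorophenyl in place of 3-fluorophenyl on an amide-type nitrogen. Among the measured compounds shown here, no measured step makes this exact exchange. The nearest comparison is a 2.7-fold higher number from compound 2 to compound 3 (0.43 log units; beyond the scatter), where a single halogen on the same aromatic ring of the anilide changed by a modest amount; the two steps from compound 1 show that replacing propyl with either carbamoyl group moves the number only within or just beyond the scatter. A second fluorine on that ring is therefore expected to shift this assay by no more than a modest amount, direction uncertain. Compound 4 is estimated at 80 ug/mL, with a range from 35 ug/mL to 180 ug/mL, so that the expected step of a 1.2-fold lower number from compound 3 to compound 4 (0.09 log units; within the scatter) stays within the scatter.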

Compound 4, half-maximal inhibitory concentration: 43.3 ug/mL
Compound 4: the middle estimate sits 1.8-fold (0.27 log units) above what was measured; the measured number falls inside the stated range.
By their numbers in this assay, from the lowest: compounds 2, 4 and 1 (each within the scatter of the next); then compound 3.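

In this assay, the ring on the amide-type nitrogen carries two fluorines without the number rising further: 2,6-difluorophenyl in place of 3-fluorophenyl gives a 2.3-fold lower number from compound 3 to compound 4 (0.36 log units; beyond the scatter), a modest step beyond the scatter, so fluorine on this ring does not by itself go with the higher number. Putting 2,6-difluorophenyl in place of 3-chlorophenyl gives a 1.2-fold higher number from compound 2 to compound 4 (0.07 log units; within the scatter), and putting (2,6-difluorophenyl)carbamoyl in place of propyl gives a 1.1-fold lower number from compound 1 to compound 4 (0.03 log units; within the scatter), both within the scatter, so three of the four compounds now stand together and only the 3-fluorophenyl anilide stands apart. No measurement offered here explains why the two fluorine patterns differ.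

The compounds shown cannot separate the number of fluorines from where they sit, and they leave open how a plain phenyl, or a phenyl bearing an amine or a carboxylic acid, would read on the amide-type nitrogen. They also leave open whether a longer chain in place of propyl would move the number in this assay.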